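The compounds below may be only part of what the source reports. "The series", "measured", "known", "first", "only" and "open" are said of these compounds alone.

Measured so far:
compound 1, `COc1ccc(S(=O)(=O)N2CCCC[C@H]2C(=O)O[C@@H](Cc2c(Cl)c[n+]([O-])cc2Cl)c2ccc(OC(F)F)c(OCC3CC3)c2)cc1C(=O)N(C)C`, gives 132 nm/s in an ADME assay on Caco-2 cells (Homo sapiens) for permeability, read by LC-MS, in the apical to basolateral direction, with a stated time of 2 h, tested at 10 uM; a lower number here means that the compound crosses the layer more slowly, a higher number that the compound crosses the layer faster;
compound 2, `CN(C)C(=O)c1cccc(S(=O)(=O)N2CSC[C@H]2C(=O)O[C@@H](Cc2c(Cl)c[n+]([O-])cc2Cl)c2ccc(OC(F)F)c(OCC3CC3)c2)c1`, gives 28 nm/s in this assay.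

Compound 1 holds the higher of the two numbers recorded in this assay; compound 2 stands a good way lower, a gap beyond the scatter. Compound 3, `CN(C)C(=O)c1cccc(S(=O)(=O)N2CCCC[C@H]2C(=O)O[C@@H](Cc2c(Cl)c[n+]([O-])cc2Cl)c2ccc(OC(F)F)c(OCC3CC3)c2)c1`, has not yet been measured. It differs from compound 1 in one place: hydrogen in place of methoxy on an aromatic carbon. Going by the values given here, no pair of measured compounds shows exactly this step, so its size must be judged from the structural change alone. The group that leaves is small and the rest of the molecule is unchanged, so only a modest step is expected, if any, in the direction of a higher number, and it may well stay within the scatter. Compound 3 is estimated at 160 nm/s, with a range from 80 nm/s to 320 nm/s, which amounts to an expected step of a 1.2-fold higher number from compound 1 to compound 3 (0.08 log units; within the scatter).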

Compound 3, apparent permeability: 217 nm/s
Beside the measured number, compound 3's estimate is 1.4-fold (0.13 log units) below it, within the range that was stated.
By their numbers in this assay, from the lowest: compound 2; then compounds 1 and 3 (each within the scatter of the next).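

In this assay, going by these compounds alone, hydrogen in place of methoxy on this aromatic carbon, ortho to a dimethylcarbamoyl group, gives a 1.6-fold higher number from compound 1 to compound 3 (0.22 log units; within the scatter) and so shows that removing the methoxy leaves no step that can be told apart from the scatter. Within the data shown here, this is the first pair of measured compounds to differ in this one place, and it gives compound 1 and compound 3 no order between them in this assay. Nothing at hand bears on the reason for this result. On these data alone, whether a fluorine, an amine or a carboxylic acid on the same carbon would also stay within the scatter remains open. So does whether removing the methoxy would give a step of similar size on the core of compound 2.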